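Two quinazoline piperazines and a diaminophenyl sulfonamide

A few compounds are considered here, and "the series" means these few. Any claim that something is new, unique, unknown or untested is made for them only; others in the source may bear on it.

Compound 1: `COc1cc2nc(N3CCN(C(=O)c4ccc(C(C)(C)C)cc4)CC3)nc(N)c2cc1OC`, 47000 nM
Compound 2: `COc1cc2nc(N3CCN(S(=O)(=O)c4ccc(C(F)(F)F)cc4)CC3)nc(N)c2cc1OC`, 27000 nM

Compound 1 `COc1cc2nc(N3CCN(C(=O)c4ccc(C(C)(C)C)cc4)CC3)nc(N)c2cc1OC` carries an amide on the piperazine and, in a functional assay on PC-3 cells (Homo sapiens) for inhibition (on this read-out higher numbers stand for weaker inhibition and lower numbers for stronger inhibition), compound 1 gives 47000 nM. Compound 2 `COc1cc2nc(N3CCN(S(=O)(=O)c4ccc(C(F)(F)F)cc4)CC3)nc(N)c2cc1OC` carries a sulfonyl instead, and in this assay compound 2 gives 27000 nM. Only these two numbers are known, and the gap between compound 2 and compound 1 lies within the usual scatter of repeated measurements, so neither can be set apart from the other on this read-out.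

Compound 3 `COc1cc2nc(N3CCN(S(=O)(=O)c4ccc(N)cc4N)CC3)nc(N)c2cc1OC` keeps the sulfonyl of compound 2 and changes the aryl on it: 2,4-diaminophenyl in place of 4-(trifluoromethyl)phenyl on a sulfonyl sulfur. Among the measured compounds shown here, nothing measured here shows how this change acts, since no pair of measured compounds differs in this place. For the measured compounds named here, the sole known pair, compound 1 and compound 2, shows only two numbers within the scatter of each other.

The step from compound 2 to compound 3 is therefore expected to stay within the scatter, in either direction, as a 1.1-fold higher number from compound 2 to compound 3 (0.05 log units; within the scatter). For compound 3 the value in this assay is estimated at 30000 nM, with a range from 8000 nM to 110000 nM.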

Compound 3, half-maximal inhibitory concentration: 67000 nM
Beside the measured number, compound 3's estimate is 2.2-fold (0.35 log units) below it; low and high end bracket the measured number.
By their numbers in this assay, from the lowest: compounds 2, 1 and 3 (each within the scatter of the next, the first and the last beyond it).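

Among the compounds shown here, compound 2 and compound 3 give the first comparison that can be read at this position, the aryl group on a sulfonyl sulfur whose other neighbour is a sulfonamide nitrogen in a ring. In this assay, 2,4-diaminophenyl in place of 4-(trifluoromethyl)phenyl gives a 2.5-fold higher number from compound 2 to compound 3 (0.39 log units; beyond the scatter), so inhibition here is modestly weaker and the read-out is not indifferent to the aryl group at this position. The change is a bundled one, since the trifluoromethyl group leaves, two amino groups enter and hydrogen-bond donors and acceptors appear where the leaving group had none, and no available measurement explains the step.

As far as these compounds go, it remains open whether the step follows the loss of the trifluoromethyl group, the arrival of the amino groups or both, and a plain phenyl or a phenyl with a single amine would help separate these. From the compounds shown here alone, it is also open whether other groups on the phenyl, such as a carboxylic acid, a methoxy group or a chlorine, would move the number in the same direction or the opposite one.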